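A few compounds are considered here, and "the series" means these few. Any claim that something is new, unique, unknown or untested is made for them only; others in the source may bear on it.

Working notes on the series. The series rests on the shared core of compound 1 `COc1ccccc1-c1cnc(NC(=O)c2ccc(F)cc2)n1C`, varied at the substituent on the imidazole nitrogen and at the acyl part of the amide. Compound 2 is `CCCCn1c(-c2ccc(OC)cc2)cnc1NC(=O)c1ccc(F)cc1` and compound 3 is `COc1ccc(-c2cnc(NC(=O)c3cccnc3)n2C)cc1`. In a toxicity assay on THP-1 cells (Homo sapiens) for inhibition (a lower number here means that less compound is tolerated, a higher number that more compound is tolerated), compound 1 gives > 100000 nM, which is a limit of the assay and not a number. In this assay compound 2 likewise gives only a limit, > 100000 nM. Compound 3 also reaches no number in this assay, its value being the limit > 100000 nM. Among the measured compounds shown here, compound 3 thus stands where every measured member stands, at the limit of > 100000 nM in this assay, at which 3 of the 3 values shown sit; no measured step can be drawn from it, and no ordering among compounds 1, 2 and 3 is possible.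

Compound 4 is `COc1ccc(-c2cnc(NC(=O)c3ccccc3)n2C)cc1`. It differs from compound 3 by phenyl in place of pyridin-3-yl on a carbonyl carbon. With the three measured values all sitting at the limit, the expected step from compound 3 to compound 4 in this assay is a number no higher from compound 3 to compound 4 (the limit leaves the size open), meaning none beyond the scatter. Compound 4 is therefore estimated in this assay at 100000 nM, within a range of 50000 nM to 300000 nM, most likely reported again as a limit.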

Compound 4, half-maximal cytotoxic concentration: > 100000 nM
Compound 4: a limit, no number (the forecaster's own chance of this, stated with the estimate: 85%); the middle value sits exactly at the limit.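

No step can be read from compound 3 to compound 4 in this assay, as both results are limits and not numbers: the limit of > 100000 nM in this assay, at which 4 of the 4 values shown sit.

The compounds shown leave open whether phenyl in place of pyridin-3-yl on a carbonyl carbon changes tolerance, and at what concentration any compound here reaches half-maximal cytotoxicity.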